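The compounds below may be only part of what the source reports. "The series", "measured", "known", "first", "only" and "open" are said of these compounds alone.

Measured so far in a functional assay on CCRF-CEM cells (Homo sapiens) for antiproliferative activity, with a stated time of 72 h; a lower number here means a stronger inhibitor, a higher number a weaker inhibitor:
- Compound 1 `OC[C@H]1O[C@@H](n2cnc3c(NCc4cccc(F)c4)ncnc32)[C@H](O)[C@@H]1O`: 4000 nM
- Compound 2 `OC[C@H]1O[C@@H](n2cnc3c(NCc4ccc(F)cc4)ncnc32)[C@H](O)[C@@H]1O`: 1250 nM
- Compound 3 `COc1cccc(CNc2ncnc3c2ncn3[C@@H]2O[C@H](CO)[C@@H](O)[C@H]2O)c1`: 7600 nM

The three compounds share a core and differ only in the substituted benzyl group. Compound 3 is not clearly separated from its nearest neighbour, as the data show a 1.9-fold higher number from compound 1 to compound 3 (0.28 log units; within the scatter). Against the remaining compound, they show a 6.1-fold higher number from compound 2 to compound 3 (0.78 log units; beyond the scatter).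

Compound 4 `OC[C@H]1O[C@@H](n2cnc3c(NCc4ccc(F)cc4F)ncnc32)[C@H](O)[C@@H]1O` keeps the shared core and changes one group, on a saturated chain carbon bound to a nitrogen on an aromatic ring: 2,4-difluorophenyl in place of 3-methoxyphenyl on a saturated chain carbon bound to a nitrogen on an aromatic ring. In words, 2,4-difluorophenyl takes the place of 3-methoxyphenyl.

Within the data shown here, no measured compound carries two fluorines, so no step shows this change directly. The closest evidence comes from the two compounds with a single fluorine. Their own comparison gives a 3.2-fold lower number from compound 1 to compound 2 (0.51 log units; beyond the scatter), so the placing of that fluorine can matter. Relative to compound 3, only compound 2 at 1250 nM is clearly apart, while compound 1 goes against any general gain from fluorine.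

A modest move towards a lower number is therefore expected, and the expected step is a 3.5-fold lower number from compound 3 to compound 4 (0.54 log units; beyond the scatter). The estimate for compound 4 is 2200 nM, with an expected range of 800 nM to 6000 nM.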

Compound 4, half-maximal inhibitory concentration: 7100 nM
Beside the measured number, compound 4's estimate is 3.2-fold (0.51 log units) below it, outside the stated range (above it).
By their numbers in this assay, from the lowest: compound 2; then compounds 1, 4 and 3 (each within the scatter of the next).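

In this assay the change from 3-methoxybenzyl to 2,4-difluorobenzyl makes no readable difference (a 1.1-fold lower number from compound 3 to compound 4 (0.03 log units; within the scatter)), and the change from 3-fluorophenyl to 2,4-difluorophenyl likewise stays within the scatter (a 1.8-fold higher number from compound 1 to compound 4 (0.25 log units; within the scatter)). The real contrast is with the 4-fluorophenyl group, where one further fluorine on the ring gives a clearly weaker compound (a 5.7-fold higher number from compound 2 to compound 4 (0.75 log units; beyond the scatter)), so a second fluorine did not build on that group's advantage but lost it. Fluorine on this ring therefore brings no general gain: compound 2 alone stands apart from the other three, while compound 1 and compound 4 also carry fluorine and are not separated from the methoxy compound 3, which means the exact pattern on the ring matters more than the mere presence of the atom.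

Nothing available here explains why the second fluorine cancels the advantage of compound 2. As far as these compounds go, it also stays open whether that advantage is special to fluorine, since a chlorine or a methyl group on the ring, or a longer chain in place of the benzyl group, could show how narrow this preference is.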